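A few compounds are considered here, and "the series" means these few. Any claim that something is new, unique, unknown or untested is made for them only; others in the source may bear on it.

Measured compounds in a functional assay on MCF7 cells (Homo sapiens) for antiproliferative activity, read by MTT assay, with a stated time of 72 h; on this read-out lower numbers stand for stronger inhibition and higher numbers for weaker inhibition:
compound 1, `O=c1cc(CSC(=S)N2CCCCC2)oc2ccccc12`: compound 1 gives > 25000 nM, a limit of the assay rather than a number.
compound 2, `O=c1c(Cl)c(CSC(=S)N2CCCCC2)oc2ccccc12`: compound 2 gives 1000 nM.
compound 3, `O=c1cc(CSC(=S)N2CCOCC2)oc2cc(Cl)ccc12`: compound 3 gives > 25000 nM, again a limit rather than a number.

Within the data shown here, compound 2 therefore holds the only actual number in this assay; the two other values sit at the limit of > 25000 nM in this assay, at which 2 of the 3 values shown sit. Among the measured compounds shown here, the single one-place step is an at least 25-fold lower number from compound 1 to compound 2 (1.39 log units; beyond the scatter), chloro in place of hydrogen on an aromatic carbon.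

Compound 4, `O=c1c(Cl)c(CSC(=S)N2CCOCC2)oc2ccccc12`, differs from compound 2 by morpholin-4-yl in place of piperidin-1-yl on a thiocarbonyl carbon. For the measured compounds named here, no measured step touches the amine on the thiocarbonyl carbon; the step from compound 1 to compound 2 concerns another place and says nothing about this one. Going by the values given here, compound 3 is the only measured compound with morpholin-4-yl, and compound 3 sits at the limit. Compound 3 also lacks the chloro that compound 2 carries, and compound 1, which lacks that chloro as well, sits at the limit too, so the morpholine swap cannot be read off on its own.

The expectation for compound 4 is thus a modest weakening at most, a 2.0-fold higher number from compound 2 to compound 4 (0.30 log units; within the scatter), with wide uncertainty. Compound 4 is estimated at 2000 nM, within 700 nM to 8000 nM.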

Compound 4, half-maximal inhibitory concentration: 11100 nM
The estimate for compound 4 lay 5.6-fold (0.74 log units) below the measured number, outside the stated range (above it).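

In this assay the amine on the thiocarbonyl carbon now has a step of its own, an 11-fold higher number from compound 2 to compound 4 (1.05 log units; beyond the scatter), with morpholin-4-yl in place of piperidin-1-yl. The two groups have the same heavy-atom count and differ by one ring oxygen in place of a ring carbon, yet this position is clearly not indifferent to the swap, and the chloro shared by compound 2 and compound 4 does not by itself hold the number. Among these compounds, compound 3, the only earlier compound with morpholin-4-yl, gives > 25000 nM, which is a limit of the assay, and it differs from compound 4 in more than one place, so only the new pair isolates this change.

Whether the ring oxygen itself accounts for the step stays open, as thiomorpholine, 4-methylpiperazine and an open-chain diethylamine are not among the compounds shown on this thiocarbonyl carbon. Also open is whether the swap gives a step of similar size without the chloro, as no pair shown reads that change on its own.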